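This account rests on a few compounds, and the source may have more. Where it says the series, first, only, none or still open, it means among the compounds named here.

Measured compounds:
compound 1 `Cn1nnnc1SCC(=O)N/N=c1/scc(-c2ccc(Br)cc2)n1-c1ccccc1`, "not determined" (no result reported) in a functional assay on C6 cells (Rattus norvegicus) for cytotoxicity, read by MTT assay, with a stated time of 24 h; on this read-out lower numbers stand for stronger inhibition and higher numbers for weaker inhibition
compound 2 `Cn1nnnc1SCC(=O)N/N=c1/scc(-c2ccc(Cl)cc2)n1-c1ccccc1`, "not determined" (no result reported) in this assay
compound 3 `Cn1cnnc1SCC(=O)N/N=c1/scc(-c2ccccc2)n1-c1ccccc1`, 68.3 ug/mL

Only compound 3 carries a number in this assay; compound 1 and compound 2 were not given one, so compound 3 is the only reference point, with nothing to rank it against.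

Compound 4 `Cn1nnnc1SCC(=O)N/N=c1/scc(-c2ccccc2)n1-c1ccccc1` differs from compound 3 in one place: 1-methyl-1H-tetrazol-5-yl in place of 4-methyl-4H-1,2,4-triazol-3-yl on a sulfur. Among the measured compounds shown here, no comparable step between two measured compounds is available, so the expected step from compound 3 to compound 4 is estimated as a 1.1-fold lower number from compound 3 to compound 4 (0.02 log units; within the scatter), a change that would stay within the usual scatter in either direction.

On that basis compound 4 is expected to give about 65 ug/mL, within the estimated range 30 ug/mL to 140 ug/mL.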

Compound 4, half-maximal inhibitory concentration: 67.7 ug/mL
Estimate against measurement, compound 4: 1.0-fold (0.02 log units) below, within the range that was stated.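

In this assay the swap of 4-methyl-4H-1,2,4-triazol-3-yl for 1-methyl-1H-tetrazol-5-yl on a sulfur gives a 1.0-fold lower number from compound 3 to compound 4 (0.00 log units; within the scatter), so the two compounds read alike. At this position, one ring with a further nitrogen and the same count of heavy atoms leaves no visible mark on the number. Nothing available explains this result.

Compound 1 and compound 2 carry no number, so their steps cannot be read. As far as these compounds go, whether an amine, a carboxylic acid or a longer chain in place of the methyl would also read alike remains open.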